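Trimming the side chain on the pyrazole nitrogen of compound 1

The compounds below may be only part of what the source reports. "The series", "measured", "known", "first", "only" and "open" are said of these compounds alone.

Measured compounds:
compound 1, `CCC(=O)c1c(-c2ccccc2)c2cc(Cl)ccc2c(=O)n1Cc1cc(S(C)(=O)=O)n(CCC(C)(C)O)n1`, 4.23
compound 2, `CCC(=O)c1c(-c2ccccc2)c2cc(Cl)ccc2c(=O)n1Cc1cc(C(=O)NC)[nH]n1`, 3.5

In a physicochemical assay for lipophilicity, at pH 7.4 (a higher number here means a more lipophilic compound, a lower number a more polar compound), compound 1 gives 4.23, the higher of the two numbers available. Compound 2 sits lower in this assay at 3.5, a gap that lies beyond the usual scatter. Among the compounds with values here, no single-point step between these two measured compounds has been recorded, so the pair only shows where each of them stands.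

Compound 3, `CCC(=O)c1c(-c2ccccc2)c2cc(Cl)ccc2c(=O)n1Cc1cc(S(C)(=O)=O)n(CC(C)=O)n1`, has not yet been measured. It differs from compound 1 in one place: acetyl in place of 2-hydroxy-2-methylpropyl on a saturated chain carbon bound to an aromatic nitrogen. The group that leaves is larger and carries a hydroxyl hydrogen, while the group that enters is smaller. For compound 3 a modest move downward in this assay is expected, the step from compound 1 to compound 3 being estimated at a number 0.43 log units lower from compound 1 to compound 3 (beyond the scatter), just at the edge of the scatter. Compound 3 is therefore estimated at 3.8, within 3.3 to 4.3.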

Compound 3, distribution coefficient: 3.79
For compound 3 the middle estimate is 0.01 log units above the measured one, within the range that was stated.
By their numbers in this assay, from the lowest: compounds 2 and 3 (each within the scatter of the next); then compound 1.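

Within the data shown here, this is the first single change that can be read in this assay: with acetyl in place of 2-hydroxy-2-methylpropyl, on a saturated chain carbon bound to an aromatic nitrogen, the step is a number 0.44 log units lower from compound 1 to compound 3 (beyond the scatter). The change alters several things at once, going from 5 heavy atoms to 3 and from 1 hydrogen-bond donor to 0 while adding a double bond, so this one step cannot divide its size among them. Among these compounds, nothing measured so far accounts for the step.

Open, on these data alone, is whether a plain propyl chain, a 2-hydroxyethyl chain or a chain ending in an amine would separate the part played by the hydroxyl hydrogen from that of chain length. Also open, as far as these compounds go, is whether the same exchange gives a step of like size on a core other than that of compound 1.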